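The source may hold more compounds than are shown below. What is called first, only, known or untested is meant among the compounds shown, and "the series" means these compounds.

Compound 1, `CC[C@@H](CCn1cncn1)c1ccccc1`: 89.9 ug/mL
Compound 2, `CC[C@@H](CCn1cncn1)c1ccc(Cl)cc1`: 55.1 ug/mL
Compound 3, `Clc1ccc([C@@H](CCn2cncn2)Cc2ccccc2)cc1`: 25.9 ug/mL

All three were run in an ADME assay on HEp-2 cells (Homo sapiens) for cytotoxicity, read by MTT assay, with a stated time of 3 days; a lower number here means that less compound is tolerated, a higher number that more compound is tolerated. Compound 1 and compound 2 share a core and differ by chloro in place of hydrogen on an aromatic carbon; this change gave a 1.6-fold lower number from compound 1 to compound 2 (0.21 log units; within the scatter). Compound 3 carries a different core, and the difference between its core and that of compound 1 is not broken down here. In this assay compound 3 gives the lowest of the three numbers, with its nearest neighbour compound 2 and its furthest compound 1 both beyond the scatter.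

Compound 4, `Clc1ccc([C@@H](CCn2cncn2)Cc2ccccc2)c(Cl)c1`, has not yet been measured. It differs from compound 3 by chloro in place of hydrogen on an aromatic carbon. This is the same kind of change as that from compound 1 to compound 2, but the place is not the same: in compound 2 the chloro sits para to a large group, whereas in compound 4 it sits ortho to a large group and meta to a chloro group. For the measured compounds named here, the one measured example of this kind of change, a 1.6-fold lower number from compound 1 to compound 2 (0.21 log units; within the scatter), stayed within the scatter, so the expected step for compound 4 is small: a 1.5-fold lower number from compound 3 to compound 4 (0.18 log units; within the scatter), resting on that earlier step. In this assay compound 4 is therefore expected to give about 17 ug/mL, with the estimate spanning 8 ug/mL to 35 ug/mL.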

Compound 4, half-maximal cytotoxic concentration: 11.1 ug/mL
For compound 4 the middle estimate is 1.5-fold (0.19 log units) above the measured one, within the range that was stated.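

In this assay, chloro in place of hydrogen on an aromatic carbon gave a 2.3-fold lower number from compound 3 to compound 4 (0.37 log units; beyond the scatter), and set beside the earlier step on the other core, the two steps do not differ: the same change on two cores in this assay, a 1.6-fold lower number (0.21 log units; within the scatter) from compound 1 to compound 2 and a 2.3-fold lower number (0.37 log units; beyond the scatter) from compound 3 to compound 4, 1.4-fold (0.16 log units) apart, within the scatter of two such steps

As far as these two pairs can tell, the change carries from the core of compound 1 to the core of compound 3 without a detectable difference in the size of its step, even though only the newer step lies beyond the scatter. This does not show that the step has one fixed size across the series, and it cannot separate the effect of the core from that of the place, since the new chloro in compound 4 sits ortho to a large group and meta to a chloro group.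

The compounds shown leave open whether a methoxy group or an amine in that same place would give a step of similar size, and whether chloro would do so there without the other chloro group present. They also leave open how the step would run on a core carrying a longer chain.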